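The compounds below may be only part of what the source reports. "The series", "measured", "known", "first", "only" and "open" are said of these compounds alone.

Compound 1 `Oc1cc(-c2ccccc2)nc2c(O)cccc12` — in a functional assay on KB cells (Homo sapiens) for cytotoxicity (on this read-out lower numbers stand for an effect already at smaller amounts and higher numbers for an effect only at larger amounts of compound), compound 1 gives > 10 ug/mL; this is a limit of the assay, not a number.
Compound 2 `CC(C)COc1cc(-c2ccccc2)nc2ccccc12` — in this assay compound 2 gives > 4 ug/mL, again a limit of the assay rather than a number.
Compound 3 `Oc1cc(-c2ccccc2)nc2cc(F)ccc12` — in this assay compound 3 gives < 0.1 ug/mL, also a limit of the assay.

Compound 2 therefore has no measured number of its own in this assay: its result sits at the limit of > 4 ug/mL in this assay, at which 1 of the 3 values shown sits, and the other two results shown are limits as well, so no step between measured compounds can be worked out here. Compound 4 `CCCCOc1cc(-c2ccccc2)nc2ccccc12` has not yet been measured in this assay. It differs from compound 2 in one place only: propyl in place of isopropyl on a saturated chain carbon bound to an oxygen on an aromatic ring. The two compounds contain the same atoms, joined differently, and the change keeps the number of donors and acceptors as counted.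

Among the compounds with values here, with no measured step to lean on, the expectation is that the move from compound 2 to compound 4 produces no change beyond the usual scatter of this assay. The step from compound 2 to compound 4 is estimated at a step that the limit leaves unreadable from compound 2 to compound 4. Compound 4 is expected to give about 6 ug/mL in this assay, within a range from 2 ug/mL to 20 ug/mL, and it may well be reported only as a limit, as compound 2 was.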

Compound 4, half-maximal effective concentration: 3.8 ug/mL
Beside the measured number, compound 4's estimate is 1.6-fold (0.20 log units) above it, and the stated range covers the measured number.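

In this assay compound 4 gives 3.8 ug/mL, the only result shown so far that is a number rather than a limit, so butoxy at this place gives the series its first firm reading. Swapping isobutoxy for butoxy therefore yields a value that can be read, and the result reads as an at least 1.0-fold lower number from compound 2 to compound 4 (0.02 log units; that floor lies within the scatter). Since that floor lies within the scatter, the data allow either almost no difference between the two chains or a larger one, and the true size stays open-ended because the reading for compound 2 is only a limit: the limit of > 4 ug/mL in this assay, at which 1 of the 4 values shown sits.

Other steps, including any to compound 1 or compound 3, cannot be read, since these compounds differ from compound 4 in more than one place and their results are limits. The compounds shown also leave open how a longer chain such as hexyl, or an amine at the end of the chain, would read at this same place on the shared core.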